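The source may hold more compounds than are shown below. What is called first, only, known or untested is meant among the compounds shown, and "the series" means these compounds.

Measured compounds, each with its result in a functional assay on A549 cells (Homo sapiens) for cytotoxicity, read by MTT assay, with a stated time of 24 h; a higher number here means a weaker inhibitor, a lower number a stronger inhibitor:

Compound 1, `C=CC1=C(C(=O)O)C(c2ccc(OC)cc2)OC1` — this value is a limit of the assay, not a number: > 100000 nM.
Compound 2, `C=CC1=C(C(=O)Nc2ccccc2)C(c2ccc(OC)cc2)OC1` — this value is also a limit of the assay: > 100000 nM.
Compound 3, `C=CC1=C(C(=O)O)C(c2ccc(OC)c(OC)c2)OC1` — this value too is a limit of the assay: > 100000 nM.

Compound 1 and compound 2 differ in one place: anilino in place of hydroxy on a carbonyl carbon. The step this change made in this assay is a step that the two limits leave unreadable from compound 1 to compound 2, since both compounds sit at the same limit and no number separates them. The two cores, that of compound 1 and that of compound 3, differ by methoxy in place of hydrogen on an aromatic carbon, and the step from one core to the other is a step that the two limits leave unreadable from compound 1 to compound 3, again hidden by the limit. Among the compounds with values here, the only evidence on all these steps is the limit of > 100000 nM in this assay, at which 3 of the 3 values shown sit.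

Compound 4, `C=CC1=C(C(=O)Nc2ccccc2)C(c2ccc(OC)c(OC)c2)OC1`, has not been measured in this assay. It differs from compound 3 by anilino in place of hydroxy on a carbonyl carbon, the same change that turns compound 1 into compound 2, made at a place described in the same words. With every measured compound at the limit, there is no sign that this change brings a compound below it, so compound 4 is expected to remain there as well; the expected step is a step that the limit leaves unreadable from compound 3 to compound 4. The estimate for compound 4 in this assay is 150000 nM, expected to lie between 50000 nM and 500000 nM, most likely reported only as a limit.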

Compound 4, half-maximal inhibitory concentration: > 100000 nM
Compound 4 ended at the assay's limit; the forecaster's own chance of this, stated with the estimate: 85%; the middle value lies beyond the limit too.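

The result for compound 4, > 100000 nM, is a limit of the assay and not a number. No size can be read for the step to compound 4 from either compound 2 or compound 3: the limit of > 100000 nM in this assay, at which 4 of the 4 values shown sit. The compounds shown leave open whether anilino in place of hydroxy, or the added methoxy, changes cytotoxicity at all, and whether any compound sharing this core falls short of the limit.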